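The source may report more compounds than this note shows. Statements on the series, on what has been measured and on what is new or still open speak of the compounds shown alone.

Measured so far:

Compound 1 `COCCn1nc(C(=O)N[C@H]2COc3ccccc3N(C)C2=S)nc1Cc1ccccc1` — in a toxicity assay on HT-29 cells (Homo sapiens) for cytotoxicity (on this read-out lower numbers stand for higher toxicity in this test and higher numbers for lower toxicity in this test), compound 1 gives > 100000 nM, which is a limit of the assay rather than a number.
Compound 2 `CN1C(=S)[C@@H](NC(=O)c2nc(Cc3ccccc3)n(C3CCC3)n2)COc2ccccc21` — in this assay compound 2 gives > 100000 nM, again a limit.
Compound 3 `CN1C(=S)[C@@H](NC(=O)c2nc(Cc3ccccc3)n(C3CCCCC3)n2)COc2ccccc21` — in this assay compound 3 gives > 100000 nM, also a limit.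

Compound 3 therefore stands where every measured compound in this series stands: the limit of > 100000 nM in this assay, at which 3 of the 3 values shown sit. Between these three compounds the steps exchange only the group on an aromatic nitrogen of the shared core, and none of them can be given a size — a step that the two limits leave unreadable from compound 1 to compound 2, a step that the two limits leave unreadable from compound 1 to compound 3 and a step that the two limits leave unreadable from compound 2 to compound 3 are all hidden by the limits on both sides.

The compound not yet measured is compound 4 `CN1C(=S)[C@@H](NC(=O)c2nc(Cc3ccccc3)n(-c3ncccn3)n2)COc2ccccc21`. Compared with compound 3 the change is pyrimidin-2-yl in place of cyclohexyl on an aromatic nitrogen. The three measured steps bear on it in so far as they also vary the group on this aromatic nitrogen, but they show only that every such variation has left the value at the limit; no size or direction can be read from them. The expectation is therefore that compound 4 also shows no measurable toxicity, with a number no higher from compound 3 to compound 4 (the limit leaves the size open) as the estimated step. Compound 4 is estimated at 100000 nM, in the range 30000 nM to 1000000 nM.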

Compound 4, half-maximal cytotoxic concentration: > 100000 nM
Compound 4: no number, only a limit; the forecaster's own chance of this, stated with the estimate: 85%; the middle value sits exactly at the limit.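

Going by these compounds alone, compound 4 joins compound 1, compound 2 and compound 3 at a limit of the assay rather than a number, so no step between any of them can be read in this assay and the sizes stay hidden: the limit of > 100000 nM in this assay, at which 4 of the 4 values shown sit.

The compounds shown leave open whether any group on this aromatic nitrogen would give a real number in this assay and how much these four compounds differ.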